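Adding a methyl to compound 1

The compounds below may be only part of what the source reports. "The series", "measured", "known", "first", "only" and "open" are said of these compounds alone.

compound 1 `CCN(CC)Cc1cccc(Nc2nc3ccccc3n2Cc2ccc(F)cc2)c1O`: > 50000 nM
compound 2 `CCN(CC)Cc1cccc(Nc2nc3ccccc3[nH]2)c1O`: > 50000 nM

In an ADME assay on CHO cells (Cricetulus griseus) for inhibition, read by MTT assay (on this read-out lower numbers stand for stronger inhibition and higher numbers for weaker inhibition), compound 1 gives > 50000 nM, which is a limit and not a number. Compound 2 gives > 50000 nM, which is likewise a limit. Both compounds therefore stand at the limit of > 50000 nM in this assay, at which 2 of the 2 values shown sit.

Compound 3 `CCN(CC)Cc1cc(C)cc(Nc2nc3ccccc3n2Cc2ccc(F)cc2)c1O` differs from compound 1 by one change: methyl in place of hydrogen on an aromatic carbon. This is methyl in place of hydrogen on an aromatic carbon, para to a hydroxy group. Among the measured compounds shown here, the only measured step changes a different place, and it is a step that the two limits leave unreadable from compound 1 to compound 2. It gives no readable size for the methyl, so no step beyond the scatter is expected in this assay, in either direction. The expected step is a number no higher from compound 1 to compound 3 (the limit leaves the size open). The estimate for compound 3 is 50000 nM, with an expected range of 25000 nM to 100000 nM.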

Compound 3, half-maximal inhibitory concentration: 18700 nM
Estimate against measurement, compound 3: 2.7-fold (0.43 log units) above, and the stated range ends above it.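

In this assay, methyl in place of hydrogen on an aromatic carbon, para to a hydroxy group, brings an at least 2.6-fold lower number from compound 1 to compound 3 (0.42 log units; beyond the scatter). This shows that the position responds to a change on the core of compound 1, whereas the earlier pair showed no readable step at all. Compound 1 stands at a limit, so the full size of the step stays open, and compound 3 is the only compound shown with a number rather than a limit: the limit of > 50000 nM in this assay, at which 2 of the 3 values shown sit.

What the compounds shown leave open is whether an ethyl, a methoxy or a chlorine at this position would lower the number further or raise it. On these data alone, it is also open whether the same methyl would lower the number on compound 2, which carries hydrogen in place of 4-fluorobenzyl.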